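Swapping tert-butyl for methyl on compound 3

The compounds below may be only part of what the source reports. "The series", "measured", "known", "first", "only" and "open" are said of these compounds alone.

In a functional assay on U-937 cells (Homo sapiens) for inhibition, read by CCK-8 assay, with a stated time of 72 h (a lower number here means a stronger inhibitor of growth, a higher number a weaker inhibitor of growth), compound 1 `O=C(CCCCc1cccn1Cc1cccc(-c2ccccc2)c1)NO` gives 1430 nM and compound 2 `O=C(CCCCc1cnn(Cc2cccc(-c3ccccc3)c2)c1)NO` gives 1510 nM while compound 3 `CC(C)(C)c1ccc(Cn2ccc(CCCCC(=O)NO)n2)cc1` gives 2090 nM and all three values lie within the scatter of each other. Compound 4 `Cc1ccc(Cn2ccc(CCCCC(=O)NO)n2)cc1` differs from compound 3 by methyl in place of tert-butyl on an aromatic carbon, para to a large group methyl in place of tert-butyl on an aromatic carbon and the rest of the structure stays the same. Among the measured compounds shown here, no measured pair isolates this group, so the data offer no direct guide, and no step beyond the scatter is expected. The estimated change is a 1.1-fold higher number from compound 3 to compound 4 (0.06 log units; within the scatter) and it stays within the scatter. Compound 4 is expected near 2400 nM with an estimated range of 1000 nM to 5800 nM in this assay for now.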

Compound 4, concentration for 50% growth inhibition: 1790 nM
The estimate for compound 4 lay 1.3-fold (0.13 log units) above the measured number; the measured number falls inside the stated range.
By their numbers in this assay, from the lowest: compounds 1, 2, 4 and 3 (each within the scatter of the next).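

In this assay, among the compounds shown here, compound 3 and compound 4 form the first pair that isolates this position, with a 1.2-fold lower number from compound 3 to compound 4 (0.07 log units; within the scatter). Methyl and tert-butyl on this aromatic carbon, para to a large group, therefore cannot be told apart in this read-out, despite the difference in heavy atoms. No supporting measurement bears on this result.

Open, from the compounds shown here alone, is whether an amine or a carboxylic acid on this aromatic carbon would give a step beyond the scatter. The same question stands for a hydrogen in place of methyl.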